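This account rests on a few compounds, and the source may have more. Where it says the series, first, only, none or still open, it means among the compounds named here.

Of the compounds shown here, three sharing one core have been measured so far. Compound 1 `CNC(=O)c1cc(Oc2ccc(NC(=O)c3cc4cccnc4n(-c4ccccc4F)c3=O)cc2)ccn1` gives 3360 nM in a functional assay on U-87MG ATCC cells for antiproliferative activity against U-87 MG (Homo sapiens), read by MTT assay, with a stated time of 72 h; a lower number here means a stronger inhibitor, a higher number a weaker inhibitor. Compound 2 `CCNC(=O)c1cc(Oc2ccc(NC(=O)c3cc4cccnc4n(-c4ccccc4F)c3=O)cc2)ccn1` gives 3250 nM, and compound 3 `CCCNC(=O)c1cc(Oc2ccc(NC(=O)c3cc4cccnc4n(-c4ccccc4F)c3=O)cc2)ccn1` gives 2320 nM. Compound 3 has the lowest of the three numbers, yet its distances to the other two are small: a 1.4-fold lower number from compound 1 to compound 3 (0.16 log units; within the scatter) and a 1.4-fold lower number from compound 2 to compound 3 (0.15 log units; within the scatter), and likewise a 1.0-fold lower number from compound 1 to compound 2 (0.01 log units; within the scatter). All three values therefore sit within the usual scatter of one another, and no order among them can be claimed.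

Compound 4 `CCCNC(=O)c1cc(Oc2ccc(NC(=O)c3cc4cccnc4n(-c4ccc(C(F)(F)F)cc4Cl)c3=O)cc2)ccn1` departs from compound 3 at a different place from any change measured so far: 2-chloro-4-(trifluoromethyl)phenyl in place of 2-fluorophenyl on an aromatic nitrogen. The three measured steps all concern the chain on the amide nitrogen, and every one of them stayed within the scatter; none touches the group on the aromatic nitrogen. Among the measured compounds shown here, there is thus no measured step that bears on this change, and any expectation rests on the change itself rather than on a precedent within this set. With that caution, compound 4 is expected to give roughly 1200 nM in this assay, within a wide range from 300 nM to 4000 nM, which corresponds to an expected step of a 1.9-fold lower number from compound 3 to compound 4 (0.29 log units; within the scatter) from compound 3 to compound 4.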

Compound 4, half-maximal inhibitory concentration: 10900 nM
Compound 4: middle estimate off by 9.1-fold (0.96 log units), on the low side; the whole stated range lies below it.
By their numbers in this assay, from the lowest: compounds 3, 2 and 1 (each within the scatter of the next); then compound 4.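

In this assay, the group on the aromatic nitrogen matters in a way the chain on the amide nitrogen has not so far: the swap gives a 4.7-fold higher number from compound 3 to compound 4 (0.67 log units; beyond the scatter), whereas all three steps along the chain stayed within the scatter. Compound 4 is thus a weaker inhibitor than compound 3, so adding to this group does not by itself bring a lower number, and this position responds to change more than the chain does in these compounds. The swap also holds two differences at once, a chlorine in place of the fluorine and an added trifluoromethyl, and no measurement available here explains the rise or divides it between them.

A plain phenyl, 2-chlorophenyl and 4-(trifluoromethyl)phenyl on the same nitrogen would show whether the chlorine, the trifluoromethyl or only the two together account for the step. The compounds shown also leave open whether the group here and the chain on the amide nitrogen act independently, which a methyl or ethyl chain, or a longer butyl chain, paired with 2-chloro-4-(trifluoromethyl)phenyl could test.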